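Swapping Trifluoromethyl for Methoxy on a Weak Inhibitor

The source may report more compounds than this note shows. Statements on the series, on what has been measured and on what is new or still open speak of the compounds shown alone.

Among the measured compounds shown here, in a functional assay on Lewis lung carcinoma cells (Mus musculus) for antiproliferative activity, read by MTT assay, with a stated time of 24 h (a lower number here means a stronger inhibitor, a higher number a weaker inhibitor), compound 1 (`C=CCc1cc(-c2cccc(C(F)(F)F)c2)ccc1O`) gives 65900 nM and holds the higher of the two numbers measured so far, while compound 2 (`C=CCc1cc(C=O)c(OCC)c(-c2ccc(OCC)c(CC=C)c2)c1`) gives 31900 nM and is the stronger inhibitor of the pair. For the measured compounds named here, these two compounds differ in more than one place, so they show no measured step for any single change.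

The next compound, compound 3 (`C=CCc1cc(-c2cccc(OC)c2)ccc1O`), keeps the core of compound 1 and changes one group. It carries methoxy in place of trifluoromethyl on an aromatic carbon, meta to a large group (methoxy in place of trifluoromethyl on an aromatic carbon). Going by the values given here, no measured pair shows what this exchange does, so any expectation here is only loosely supported. In this assay a small step is expected, with a slight lean towards a lower number and no shift beyond the scatter. The estimated step is a 1.3-fold lower number from compound 1 to compound 3 (0.12 log units; within the scatter) and that leaves the direction open. Compound 3 is estimated at 50000 nM with 20000 nM to 120000 nM as its expected range.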

Compound 3, half-maximal inhibitory concentration: > 100000 nM
Compound 3 gave a limit, no number (the forecaster's own chance of this, stated with the estimate: 15%); middle value at least 2.0-fold (0.30 log units) away from the limit.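

In this assay compound 3 gives > 100000 nM as a limit of the assay and not a number. Among the compounds shown here, this is the first measured reading for methoxy in place of trifluoromethyl on an aromatic carbon, meta to a large group, and it comes out as an at least 1.5-fold higher number from compound 1 to compound 3 (0.18 log units; that floor lies within the scatter) on the core of compound 1. The exchange therefore brings no gain in this assay, and the step has only a floor, with its true size unknown, as one fact about the data makes plain: the limit of > 100000 nM in this assay, at which 1 of the 3 values shown sits.

The compounds shown compare only trifluoromethyl and methoxy at this position, so what an amine, a carboxylic acid or a longer chain such as ethoxy would do there remains open. Also open, on these data alone, is whether the same exchange would act alike on a different core, and how far above the floor the real step for compound 3 lies.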